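From a Nitro Group to a Methoxy Group on the Benzyl Ether

The compounds below may be only part of what the source reports. "The series", "measured", "known", "first", "only" and "open" are said of these compounds alone.

Of the compounds shown here, three sharing one core have been measured in a functional assay on spleen for antagonist activity at Alpha-1B adrenergic receptor (Rattus norvegicus); on this read-out lower numbers stand for lower potency and higher numbers for higher potency (the scale is a negative logarithm). Compound 1 `COc1cccc(OC)c1OCCNCCOc1ccccc1OCc1ccc(C)cc1` gives 8.43. Compound 2 `COc1cccc(OC)c1OCCNCCOc1ccccc1OCc1cccc([N+](=O)[O-])c1` gives 8.74, and compound 3 `COc1cccc(OC)c1OCCNCCOc1ccccc1OCc1ccc([N+](=O)[O-])cc1` gives 9.02. Compound 3 therefore holds the highest of the three numbers: one of the two steps leading to it is a number 0.28 log units higher from compound 2 to compound 3 (within the scatter), which settles no order between those two compounds, while the other step is a number 0.59 log units higher from compound 1 to compound 3 (beyond the scatter).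

Compound 4 `COc1ccccc1COc1ccccc1OCCNCCOc1c(OC)cccc1OC` has not been measured. It differs from compound 3 by 2-methoxyphenyl in place of 4-nitrophenyl on a saturated chain carbon bound to an oxygen on an aromatic ring. Among the compounds with values here, two measured steps bear on this part of the molecule. Putting nitro in place of methyl on the aromatic carbon gave a number 0.59 log units higher from compound 1 to compound 3 (beyond the scatter), and exchanging 4-methylphenyl for 3-nitrophenyl gave a number 0.31 log units higher from compound 1 to compound 2 (beyond the scatter). Both say that the group carried on this saturated chain carbon shifts the read-out only modestly, with the nitro-bearing groups giving the higher numbers. Compound 4 removes the nitro group entirely and brings in a methoxy group, for which no measurement exists in this set. Within the data shown here, compound 1, with 8.43, is the only measured compound without a nitro group and sits lowest of the three. For compound 4 a modest drop is therefore expected, a number 0.52 log units lower from compound 3 to compound 4 (beyond the scatter). For compound 4 the estimate in this assay is 8.5, with a range from 8 to 9.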

Compound 4, negative logarithm of the antagonist equilibrium constant: 8.13
Compound 4: the middle estimate sits 0.37 log units above what was measured, and the stated range covers the measured number.
By their numbers in this assay, from the lowest: compounds 4 and 1 (each within the scatter of the next); then compounds 2 and 3 (each within the scatter of the next).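

In this assay, the 2-methoxyphenyl group on this saturated chain carbon sits well apart from both nitro-bearing groups: the change gives a number 0.89 log units lower from compound 3 to compound 4 (beyond the scatter), the largest step in this set, and a number 0.61 log units lower from compound 2 to compound 4 (beyond the scatter). Against the 4-methylphenyl group the same exchange gives a number 0.30 log units lower from compound 1 to compound 4 (within the scatter), so compound 1 and compound 4 cannot be told apart, even though their groups differ in both kind and placement. All four compounds now fall into two groups, with the two lacking a nitro group on one side and the two carrying one on the other, and no measurement shown here explains this split.

The compounds shown cannot separate the effect of the methoxy group itself from the effect of where it stands on the ring, and the same methoxy group elsewhere on this ring would be needed to do that. From the compounds shown here alone, it also remains open whether another group on this ring, such as a nitrile or a carboxylic acid, could match the numbers of compound 2 and compound 3.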